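Replacing the methoxyphenyl urea of compound 3 with dimethylphenyl

A few compounds are considered here, and "the series" means these few. Any claim that something is new, unique, unknown or untested is made for them only; others in the source may bear on it.

The series shares one core, seen in compound 1 `Cc1cc(C)cc(NC(=O)NCCNS(=O)(=O)c2ccc(-c3ccccc3OCc3ccccc3)s2)c1`, compound 2 `O=C(NCCNS(=O)(=O)c1ccc(-c2ccccc2OCc2cccc(O)c2)s1)Nc1cc(Cl)cc(Cl)c1` and compound 3 `COc1ccc(NC(=O)NCCNS(=O)(=O)c2ccc(-c3ccccc3OCc3cccc(O)c3)s2)cc1`. In a functional assay on HL-60 cells (Homo sapiens) for inhibition, read by CCK-8 assay, with a stated time of 48 h (a higher number here means a weaker inhibitor, a lower number a stronger inhibitor), compound 1 gives 2200 nM, and compound 2 gives 2800 nM. Compound 3 reaches only the limit of this assay, > 20000 nM, so no number is known for it. For the measured compounds named here, the one comparable step recorded, an at least 7.1-fold higher number from compound 2 to compound 3 (0.85 log units; beyond the scatter), rests on that limit (the limit of > 20000 nM in this assay, at which 1 of the 3 values shown sits), so its true size is unknown beyond its lower bound. Compound 4 `Cc1cc(C)cc(NC(=O)NCCNS(=O)(=O)c2ccc(-c3ccccc3OCc3cccc(O)c3)s2)c1` is not yet measured in this assay. It differs from compound 3 as follows: 3,5-dimethylphenyl in place of 4-methoxyphenyl on an amide-type nitrogen. Compound 1 carries the same 3,5-dimethylphenyl urea and gives a clear number, and compound 2, with 3,5-dichlorophenyl, sits in the same region, so compound 4 is expected to recover potency, with the step from compound 3 estimated as an at least 8.0-fold lower number from compound 3 to compound 4 (0.90 log units; beyond the scatter). Compound 4 is therefore estimated at 2500 nM, between 1200 nM and 6000 nM.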

Compound 4, half-maximal inhibitory concentration: > 20000 nM
Compound 4: no number, only a limit (the forecaster's own chance of this, stated with the estimate: 10%); middle value at least 8.0-fold (0.90 log units) from the limit.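

In this assay, hydroxy in place of hydrogen on an aromatic carbon gives an at least 9.0-fold higher number from compound 1 to compound 4 (0.95 log units; beyond the scatter), where the figure for compound 4 is a limit, so the 3,5-dimethylphenyl urea does not by itself keep a measured value in this series. With the hydroxy kept, 3,5-dimethylphenyl in place of 3,5-dichlorophenyl on an amide-type nitrogen gives an at least 7.1-fold higher number from compound 2 to compound 4 (0.85 log units; beyond the scatter), which leaves 3,5-dichlorophenyl as the only group at this position shown with a number alongside the hydroxy. The step between compound 3 and compound 4 cannot be read because both stand at a limit: the limit of > 20000 nM in this assay, at which 2 of the 4 values shown sit.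

On these data alone, how far past that limit compound 3 and compound 4 lie remains unknown. Also open, as far as these compounds go, is whether an amine or a carboxylic acid in place of the hydroxy, or 3,5-difluorophenyl on the urea nitrogen, would return a number.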